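The source may hold more compounds than are shown below. What is called first, only, known or untested is meant among the compounds shown, and "the series" means these compounds.

In an in vitro ADME assay on microsomes from liver (Homo sapiens) for metabolic stability, tested at 1 uM (a higher number here means that the compound lasts longer, a lower number that the compound disappears faster), compound 1 (`CNC(=O)c1cc(N)c(Nc2ccc(C#N)cc2)cc1Oc1c(C)cc(CCC#N)cc1C`) gives 0.928 h and compound 2 (`COC(=O)c1cc(N)c(Nc2ccc(C#N)cc2)cc1Oc1c(C)cc(/C=C/C#N)cc1C`) gives 4.72 h while compound 3 (`Cc1cc(/C=C/C#N)cc(C)c1Oc1cc(Nc2ccc(C#N)cc2)c(N)cc1CO`) gives 0.503 h as its half-life. Compound 3 lies within the scatter of compound 1 and is clearly separated from compound 2.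

The next structure is compound 4 (`CNC(=O)c1cc(N)c(Nc2ccc(C#N)cc2)cc1Oc1c(C)cc(/C=C/C#N)cc1C`), which has methylcarbamoyl in place of hydroxymethyl on an aromatic carbon. The group sits para to a (4-cyanophenyl)amino group.

Within the data shown here, one measured step bears directly on this place: a 9.4-fold lower number from compound 2 to compound 3 (0.97 log units; beyond the scatter) for hydroxymethyl in place of methoxycarbonyl. Among the measured compounds shown here, it shows that the number in this assay can shift by a clear margin with the group at this carbon, but methylcarbamoyl plays no part in that step. The closest guide to methylcarbamoyl is compound 1 at 0.928 h (same methylcarbamoyl, different nitrile-bearing chain), and that value lies within the scatter of compound 3. For the measured compounds named here, no measurement yet shows methylcarbamoyl together with the chain of compound 4, so the reading from compound 1 is only indirect.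

A modest upward move, a 2.4-fold higher number from compound 3 to compound 4 (0.38 log units; beyond the scatter) as the expected size, is therefore the working estimate, far short of the value of the ester. Compound 4 is estimated at 1.2 h (expected range 0.45 h to 3.2 h).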

Compound 4, half-life in the Homo sapiens assay: 0.747 h
Compound 4: the middle estimate sits 1.6-fold (0.21 log units) above what was measured; measured number inside the range.
By their numbers in the Homo sapiens assay, from the lowest: compounds 3, 4 and 1 (each within the scatter of the next); then compound 2.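

In the Homo sapiens assay, methylcarbamoyl and hydroxymethyl at this carbon cannot be told apart, a 1.5-fold higher number from compound 3 to compound 4 (0.17 log units; within the scatter), while methoxycarbonyl stays clearly separated from methylcarbamoyl, a 6.3-fold lower number from compound 2 to compound 4 (0.80 log units; beyond the scatter), so among the three groups shown at this position only the ester stands apart. With methylcarbamoyl held fixed, the chain also makes no readable difference in the Homo sapiens assay, a 1.2-fold lower number from compound 1 to compound 4 (0.09 log units; within the scatter), so 2-cyanoethenyl and 2-cyanoethyl cannot be separated in this pair. In a physicochemical assay for solubility, with a stated time of 4 h, at pH 2.0 (a higher number here means a more soluble compound, a lower number a less soluble compound), compound 3 gives 20.9 ug/mL and compound 4 gives 8.63 ug/mL. The swap from hydroxymethyl to methylcarbamoyl, silent for half-life, does register in the physicochemical assay: the measured solubility of compound 3, 20.9 ug/mL, and of compound 4, 8.63 ug/mL, a 2.4-fold lower number (0.38 log units; beyond the scatter)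

As far as these compounds go, whether the half-life of compound 2 is particular to methoxycarbonyl or extends to other groups at this carbon, such as ethoxycarbonyl or a carboxylic acid, remains open. Also open, from the compounds shown here alone, is where a dimethylcarbamoyl group at this carbon would fall in either read-out, and so whether the amide hydrogen matters to the separation from the ester.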